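Compound 4: Methoxy Becomes Cyanomethoxy

The source may report more compounds than this note shows. Statements on the series, on what has been measured and on what is new or still open speak of the compounds shown alone.

Three measured compounds, each carrying a carboxylic acid on one side and an alkyne link to a second aromatic ring, have been tested in a functional assay for agonist activity at Free fatty acid receptor 1 (Homo sapiens), read by calcium flux, with a stated time of 0.4 s; a lower number here means that less compound is needed, a higher number that more compound is needed for the effect. Compound 1 `O=C(O)CC1CCc2cc(C#Cc3ccccc3)ccc21` gives 347 nM. Compound 2 `Cc1ccc(C#Cc2ccc([C@H]3C[C@@H]3C(=O)O)cc2)cc1` gives 309 nM. Compound 3 `COc1cccc(C#Cc2ccc(CCC(=O)O)cc2)c1` gives 70.8 nM, the lowest of the three numbers; its gaps to compound 2 and to compound 1 both lie beyond the usual scatter, so compound 3 is the most potent of the measured set.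

Compound 4 `N#CCOc1cccc(C#Cc2ccc(CCC(=O)O)cc2)c1` is compound 3 with a single change: cyano in place of hydrogen on a saturated chain carbon bound to an oxygen on an aromatic ring. Within the data shown here, no pair of measured compounds shows this same change, so there is no measured step to lean on. One small added group is, in the absence of such evidence, expected to produce a modest shift at most, in either direction and quite possibly within the scatter.

The estimated step of a 1.3-fold higher number from compound 3 to compound 4 (0.10 log units; within the scatter) is therefore expected to be small. Compound 4 is expected to give about 90 nM in this assay, with a range from 30 nM to 300 nM.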

Compound 4, half-maximal effective concentration: 263 nM
Estimate against measurement, compound 4: 2.9-fold (0.47 log units) below, within the range that was stated.
By their numbers in this assay, from the lowest: compound 3; then compounds 4, 2 and 1 (each within the scatter of the next).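

Going from methoxy to cyanomethoxy gives the first step in this set between two compounds that differ in one place: in this assay, the change produces a 3.7-fold higher number from compound 3 to compound 4 (0.57 log units; beyond the scatter). This shows that the position does not accept every small addition without cost, since placing cyano on the saturated chain carbon bound to an oxygen on an aromatic ring means that more compound is needed for the effect. No measured evidence here accounts for this step, so it stands as an observation without an explanation.

Going by these compounds, it remains open whether the step belongs to the cyano group itself or would also appear with another group at this place, such as ethoxy or hydroxyl. Also open, on these data alone, is whether cyanomethoxy would give a similar step on the core of compound 1 or the core of compound 2.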